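From 4-nitrophenyl to 4-chlorophenyl at the assay limit

The source may hold more compounds than are shown below. What is called first, only, known or untested is meant among the compounds shown, and "the series" means these compounds.

Measured in a functional assay on HT-29 cells (Homo sapiens) for cytotoxicity, read by sulforhodamine B assay; on this read-out lower numbers stand for higher toxicity in this test and higher numbers for lower toxicity in this test:
- compound 1 `CC1=CC[C@@H]([C@@](C)(O)CCCC(C)(C)NC(=S)N/N=C\c2ccc(C)cc2)CC1` gives > 100000 nM (a limit)
- compound 2 `CC1=CC[C@@H]([C@@](C)(O)CCCC(C)(C)NC(=S)N/N=C\c2cccc([N+](=O)[O-])c2)CC1` gives > 100000 nM (a limit)
- compound 3 `CC1=CC[C@@H]([C@@](C)(O)CCCC(C)(C)NC(=S)N/N=C\c2ccc([N+](=O)[O-])cc2)CC1` gives > 100000 nM (a limit)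

Compound 3 therefore stands at a limit and not at a number, as do both of the other measured compounds, and the limit of > 100000 nM in this assay, at which 3 of the 3 values shown sit, is all the series shows so far. Compound 4 `CC1=CC[C@@H]([C@@](C)(O)CCCC(C)(C)NC(=S)N/N=C\c2ccc(Cl)cc2)CC1` carries chloro in place of nitro on an aromatic carbon, para to a large group chloro in place of nitro on an aromatic carbon and otherwise keeps the structure of compound 3.

For the measured compounds named here, the nearest precedent is a step that the two limits leave unreadable from compound 1 to compound 3, where the same place was changed. Two further changes on this aromatic ring are a step that the two limits leave unreadable from compound 1 to compound 2 and a step that the two limits leave unreadable from compound 2 to compound 3. Going by the values given here, none has a readable size, so no step of measurable size is expected in this assay, and compound 4 is expected to remain at the limit.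

The expected change is a number no higher from compound 3 to compound 4 (the limit leaves the size open) by this estimate. For compound 4 the estimated value is 100000 nM, with an expected range from 40000 nM to 200000 nM overall.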

Compound 4, concentration lethal to 50% of the cells: 47300 nM
The estimate for compound 4 lay 2.1-fold (0.33 log units) above the measured number; the range from low to high includes it.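

In this assay compound 4 is the first compound shown to give a number rather than a limit, so a change on this aromatic carbon, para to a large group, can bring the read-out within range: chloro in place of nitro gives an at least 2.1-fold lower number from compound 3 to compound 4 (0.32 log units; beyond the scatter). The two other comparisons point the same way, with an at least 2.1-fold lower number from compound 2 to compound 4 (0.32 log units; beyond the scatter) and an at least 2.1-fold lower number from compound 1 to compound 4 (0.32 log units; beyond the scatter). The steps among compound 1, compound 2 and compound 3 cannot be read, and the new steps have only a lower bound on their size, with the rest of the series still at the limit: the limit of > 100000 nM in this assay, at which 3 of the 4 values shown sit.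

Going by these compounds, whether bromo, fluoro or methoxy on this aromatic carbon would also give a number stays open. With a single number in the series, no trend across the groups at this place can be drawn.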